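Solubility notes: from the amide to the methyl ester

The source may hold more compounds than are shown below. What is called first, only, known or untested is meant among the compounds shown, and "the series" means these compounds.

Values in a physicochemical assay for solubility, read by HPLC, using the shake flask method, in phosphate buffer, with a stated time of 2 h, at pH 6.5 (a higher number here means a more soluble compound, a lower number a less soluble compound), so far:
- compound 1 (`Nc1ncc(-c2ccc(C(=O)N3CCC(O)C3)cc2)nc1-c1ccc(C(F)(F)F)cc1`) gives 77000 nM in the shake flask
- compound 2 (`N#Cc1ccc(-c2cnc(N)c(-c3ccc(N)nc3)n2)cc1`) gives < 5000 nM as a limit of the assay, not a number

Among the measured compounds shown here, compound 1 holds the only true number in this small set, since the other entry is a limit. For the measured compounds named here, with so little data it is a single anchor and not a trend, and no measured pair isolates the change considered here.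

Compound 3 (`COC(=O)c1ccc(-c2cnc(N)c(-c3ccc(C(F)(F)F)cc3)n2)cc1`) keeps the core of compound 1 and has methoxy in place of 3-hydroxypyrrolidin-1-yl on a carbonyl carbon. The ring and its hydrogen-bond donor leave, and only a small group enters.

The expected move, a 19-fold lower number from compound 1 to compound 3 (1.28 log units; beyond the scatter) in size, is downward and beyond the usual scatter. Going by the values given here, this expectation rests on compound 1 at 77000 nM being the only value the new group departs from, so it remains a judgement. A report as a limit alone would not be a surprise.

In this assay compound 3 is estimated at 4000 nM (range 800 nM to 20000 nM).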

Compound 3, solubility: < 5000 nM
Compound 3 gave a limit, no number; the forecaster's own chance of this, stated with the estimate: 60%; the middle value is on the limit's open side.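

Among the compounds shown here, the change of methoxy in place of 3-hydroxypyrrolidin-1-yl on a carbonyl carbon is the first measured step at this position, and in this assay it gives an at least 15-fold lower number from compound 1 to compound 3 (1.18 log units; beyond the scatter). Compound 3 reads < 5000 nM, which is a limit of the assay and not a number. The step therefore fixes a minimum size and not a size, and it is already beyond the scatter at that minimum: the limit of < 5000 nM in this assay, at which 2 of the 3 values shown sit.

The compounds shown leave open whether the step follows the ring or the hydrogen-bond donor, since the two leave together and no compound here keeps one without the other. On the same carbonyl carbon, an unsubstituted pyrrolidin-1-yl would keep the ring without the hydroxyl, a 2-hydroxyethylamino chain would keep the hydroxyl without the ring, and a carboxylic acid in place of the methyl ester would show how far a charged group moves this read-out.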